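This account rests on a few compounds, and the source may have more. Where it says the series, first, only, none or still open, it means among the compounds named here.

Of the compounds shown here, three have been measured in an ADME assay on HepG2 cells (Homo sapiens) for cytotoxicity, read by MTT assay, with a stated time of 72 h; a higher number here means that more compound is tolerated, a lower number that less compound is tolerated. Compound 1 `CCCCCNc1nc2cc(-c3ccc(C)cc3)sc2c(=O)[nH]1` gives 4200 nM, compound 2 `CCCCCCNc1nc2cc(-c3ccc(C)cc3)sc2c(=O)[nH]1` gives 10600 nM, and compound 3 `CC(C)(C)Nc1nc2cc(-c3ccc(Br)cc3)sc2c(=O)[nH]1` gives 1400 nM. Compound 1 and compound 2 share a core and differ in one place: hydrogen in place of methyl on a saturated chain carbon, five bonds along the chain from a nitrogen on an aromatic ring. That change made the step of a 2.5-fold lower number from compound 2 to compound 1 (0.40 log units; beyond the scatter). Compound 3 has a different core; the difference between the two cores is not broken down here.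

Compound 4 `CC(C)Nc1nc2cc(-c3ccc(Br)cc3)sc2c(=O)[nH]1` has not yet been measured in this assay. It differs from compound 3 in one place: hydrogen in place of methyl on a saturated chain carbon bound to a nitrogen on an aromatic ring and two saturated chain carbons. Among the measured compounds shown here, this is the same kind of change as the one between compound 2 and compound 1, but not the same: there the methyl sat on a saturated chain carbon five bonds along the chain from a nitrogen on an aromatic ring, whereas here it sits on a saturated chain carbon bound to a nitrogen on an aromatic ring and two saturated chain carbons. In this assay, for the measured compounds named here, the expected step is a 1.3-fold lower number from compound 3 to compound 4 (0.10 log units; within the scatter), in the same direction as the earlier one but smaller, because the only earlier step of this kind is a 2.5-fold lower number from compound 2 to compound 1 (0.40 log units; beyond the scatter) and it was made on a different chain and core. Compound 4 is therefore estimated at 1100 nM, with a likely range from 500 nM to 2500 nM.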

Compound 4, half-maximal cytotoxic concentration: 13400 nM
The estimate for compound 4 lay 12-fold (1.09 log units) below the measured number; the whole stated range lies below it.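

In this assay, replacing the tert-butyl group with isopropyl gave a 9.6-fold higher number from compound 3 to compound 4 (0.98 log units; beyond the scatter), so losing a single methyl can matter a great deal in this series. Set beside the earlier step, the same kind of change, hydrogen in place of methyl, did not carry over from one core to the other in either size or direction: the same change on two cores in this assay, a 2.5-fold lower number (0.40 log units; beyond the scatter) from compound 2 to compound 1 and a 9.6-fold higher number (0.98 log units; beyond the scatter) from compound 3 to compound 4, 24-fold (1.38 log units) apart, beyond the scatter of two such steps This does not show why the two steps differ, since the methyl sits at a different place on a different chain and the cores differ too, so one step on each side cannot separate these factors.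

From the compounds shown here alone, it remains open how an ethyl group or a longer branched chain in place of the isopropyl group would read on the core of compound 4. Also open, going by these compounds, is whether the change from tert-butyl to isopropyl on the core of compound 1 would give the same step, which would help to separate the effect of the core from that of the chain.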